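A few compounds are considered here, and "the series" means these few. Any claim that something is new, unique, unknown or untested is made for them only; others in the source may bear on it.

Measured so far in a functional assay on Raji cells (Homo sapiens) for antiproliferative activity, read by MTT assay, with a stated time of 6 days; on this read-out lower numbers stand for stronger inhibition and higher numbers for weaker inhibition:

compound 1 `COc1ccc(/C=C/C(=O)OC[C@@H](OCc2ccccc2)[C@H]2OC(=O)C=C[C@H]2OCc2ccccc2)cc1` — 690 nM
compound 2 `CC(=O)OC[C@@H](OCc1ccccc1)[C@H]1OC(=O)C=C[C@H]1OCc1ccccc1` — 1820 nM

Within the data shown here, compound 2 holds the higher of the two numbers in this assay, with compound 1 as its only neighbour; the gap between them is a 2.6-fold higher number from compound 1 to compound 2 (0.42 log units; beyond the scatter), so compound 2 is the weaker of the pair beyond the usual scatter.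

The next compound, compound 3 `O=C1C=C[C@@H](OCc2ccccc2)[C@@H]([C@@H](CO)OCc2ccccc2)O1`, differs from compound 2 in a single place: hydrogen in place of acetyl on an oxygen on a saturated carbon. The shared core and both benzyl ethers remain as in compound 2.

Among the measured compounds shown here, only one measured step bears on this change, and only loosely. Replacing the 2-(4-methoxyphenyl)ethenyl group on the carbonyl carbon by methyl gave a 2.6-fold higher number from compound 1 to compound 2 (0.42 log units; beyond the scatter), a modest loss. For the measured compounds named here, removing the acetyl altogether continues in the same direction of trimming this ester, but there is no measured example of the free hydroxymethyl, so the direction is not fixed by data. A further modest loss is expected, in the range a 1.8-fold higher number from compound 2 to compound 3 (0.25 log units; within the scatter), though a result within the scatter of compound 2 would not be surprising. Compound 3 is therefore estimated at 3200 nM, between 1200 nM and 9000 nM.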

Compound 3, half-maximal inhibitory concentration: 10 nM
Estimate against measurement, compound 3: 320-fold (2.51 log units) above, outside the stated range (below it).
By their numbers in this assay, from the lowest: compound 3; then compound 1; then compound 2.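

In this assay, this oxygen on a saturated carbon proves far more sensitive than the earlier pair suggested: acetoxy to hydroxy gives a 180-fold lower number from compound 2 to compound 3 (2.26 log units; beyond the scatter), and replacing the (2-(4-methoxyphenyl)ethenyl)carbonyl group with hydrogen gives a 69-fold lower number from compound 1 to compound 3 (1.84 log units; beyond the scatter). Both steps are large and run opposite to the trend that the two esters alone might have suggested, as the change from one ester to the other gives only a 2.6-fold higher number from compound 1 to compound 2 (0.42 log units; beyond the scatter). Across these three compounds, the main divide at this position therefore lies between an acylated oxygen and a free hydroxy, rather than between one acyl group and another, and nothing available accounts for the size of that divide.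

The compounds shown leave open whether the free hydroxy is specifically required or whether other non-ester groups on this saturated carbon, such as a methyl ether, an amine or a carboxylic acid, would give similarly low numbers. They also leave open whether the gain from the free hydroxy holds when either benzyl ether is changed, as both remain in place in all three compounds.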